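A few compounds are considered here, and "the series" means these few. Any claim that something is new, unique, unknown or untested is made for them only; others in the source may bear on it.

Three compounds share one core and differ only in the group carried on one aromatic carbon of that core. Compound 1 `CC(C)(C)Cc1c(-c2cccnc2)sc(N)c1C(=O)c1ccc(Cl)cc1` carries pyridin-3-yl there, and in an assay on CHO cells for displacement of a labelled ligand from adenosine receptor A1 (Homo sapiens), read by scintillation counting, tested at 10 uM (a lower number here means less inhibition, a higher number more inhibition at the concentration tested (going by the name of the read-out)), compound 1 gives 1%. Compound 2 `CC(C)(C)Cc1c(/C=C/c2ccc(Cl)cc2)sc(N)c1C(=O)c1ccc(Cl)cc1` carries 2-(4-chlorophenyl)ethenyl, and in this assay compound 2 gives 1%. Compound 3 `CC(C)(C)Cc1c(-c2ccccc2)sc(N)c1C(=O)c1ccc(Cl)cc1` carries phenyl, and in this assay compound 3 gives 1%. The three steps between them, no change at the digits printed from compound 1 to compound 2 (within the scatter), no change at the digits printed from compound 1 to compound 3 (within the scatter) and no change at the digits printed from compound 2 to compound 3 (within the scatter), all lie within the scatter, so compound 3 stands level with compound 1 and compound 2, and none of the three shows meaningful inhibition at the concentration tested.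

Compound 4 `Cc1ccc(C(=O)c2c(N)sc(-c3ccccc3)c2CC(C)(C)C)cc1` differs from compound 3 in a different place: methyl in place of chloro on an aromatic carbon. The change sits on an aromatic carbon of a six-membered aromatic ring of carbon only, para to a large group. Going by the values given here, none of the measured steps touches this ring; each of them swaps the group on the other aromatic carbon, and each, as no change at the digits printed from compound 1 to compound 3 (within the scatter) shows, left the read-out unchanged. Among the compounds with values here, no measured step therefore bears directly on this change, and the data give no ground to expect a step beyond the scatter in this assay. The step from compound 3 to compound 4 is expected to be a number 1 percentage points higher from compound 3 to compound 4 (within the scatter). Compound 4 is estimated at 2%, with a range from -5% to 12%.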

Compound 4, a percentage reported as inhibition, at one concentration (the size of the read-out at that concentration, not a potency): 1%
Beside the measured number, compound 4's estimate is 1 percentage points above it; measured number inside the range.
By their numbers in this assay, from the lowest: compounds 1, 2, 3 and 4 (each within the scatter of the next).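

Going by these compounds alone, this is the first measured change on the six-membered aromatic ring of carbon only, a swap from 4-chlorophenyl to 4-methylphenyl, and in this assay it gives no change at the digits printed from compound 3 to compound 4 (within the scatter). A second place on the shared core has therefore been varied, here by exchanging one heavy atom for one heavy atom, and still no meaningful inhibition appears at the concentration tested; since compound 3 already showed none, the step cannot reveal whether this place matters for activity at this receptor. Nothing in the data available accounts for this flat result.

The compounds shown leave open whether a markedly different group at this place, such as an amine, a carboxylic acid or a longer alkyl chain in place of the methyl, would lift the read-out in this assay above that of compound 3. They also leave open whether a methyl or a chloro at this place would make any difference on a version of the core that shows real inhibition.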